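Shortening the side chain from compound 3 to compound 4

The compounds below may be only part of what the source reports. "The series", "measured", "known", "first", "only" and "open" are said of these compounds alone.

compound 1 `CC(C)(C)C1=CC(=O)C=C(NCC(=O)O)C1=O`: 85000 nM
compound 2 `CC(C)(C)C1=CC(=O)C=CC1=O`: 15500 nM
compound 3 `CC(C)C[C@H](NC1=CC(=O)C=C(C(C)(C)C)C1=O)C(=O)O`: 76500 nM

All three values come from a functional assay on K562 cells (Homo sapiens) for cytotoxicity, read by MTT assay, with a stated time of 72 h; a lower number here means a stronger inhibitor, a higher number a weaker inhibitor. Compound 3 stands within the scatter of compound 1, and compound 2 lies lower than both, beyond the scatter. Compound 4 `C[C@H](NC1=CC(=O)C=C(C(C)(C)C)C1=O)C(=O)O` carries hydrogen in place of isopropyl on a saturated chain carbon, two bonds along the chain from an amine nitrogen and a carbonyl carbon. The closest measured evidence, a 1.1-fold lower number from compound 1 to compound 3 (0.05 log units; within the scatter), changes the same chain and stays within the scatter. The larger 5.5-fold lower number from compound 1 to compound 2 (0.74 log units; beyond the scatter) removes the whole (carboxymethyl)amino group and bears on this change only weakly. No step beyond the scatter is therefore expected in this assay. The expected step is a 1.0-fold higher number from compound 3 to compound 4 (0.02 log units; within the scatter). For compound 4 the estimated value is 80000 nM, with an expected range of 42000 nM to 150000 nM.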

Compound 4, half-maximal inhibitory concentration: 77600 nM
Compound 4: the middle estimate sits 1.0-fold (0.01 log units) above what was measured; the range from low to high includes it.
By their numbers in this assay, from the lowest: compound 2; then compounds 3, 4 and 1 (each within the scatter of the next).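

In this assay, this chain position accepts hydrogen in place of isopropyl: a 1.0-fold higher number from compound 3 to compound 4 (0.01 log units; within the scatter). With a 1.1-fold lower number from compound 1 to compound 4 (0.04 log units; within the scatter), the series now reads alike with hydrogen, methyl or isobutyl on the saturated chain carbon bound to an amine nitrogen and a carbonyl carbon. Among the compounds shown here, the only step beyond the scatter still lies at the double-bonded ring carbon, where (1-carboxyethyl)amino replaces hydrogen: a 5.0-fold higher number from compound 2 to compound 4 (0.70 log units; beyond the scatter).

No measurement shown accounts for this pattern. On these data alone, whether an amide or an amine in place of the carboxylic acid would leave the number at this level remains open.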